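Isopropyl for methyl: a weak acid on the threshold

The compounds below may be only part of what the source reports. "The series", "measured", "known", "first", "only" and "open" are said of these compounds alone.

Compound 1 `CCCCC(Sc1ccc(OCCCOc2cccc(C)c2)cc1)C(=O)O` is tested in an assay for inhibition of Polyunsaturated fatty acid 5-lipoxygenase (Homo sapiens), read by HPLC, with a stated time of 10 min; a lower number here means a stronger inhibitor, a higher number a weaker inhibitor. In this assay compound 1 gives > 10000 nM, which is a limit of the assay rather than a number. Compound 2 `Cc1cccc(OCCCOc2ccc(SCC(=O)O)cc2)c1C` likewise reaches only a limit, > 10000 nM. Compound 3 `CCCCC(Sc1ccc(OCCCOc2cccc(C(F)(F)F)c2)cc1)C(=O)O`, carrying trifluoromethyl in place of methyl, gives 9800 nM in this assay. The step of an at least 1.0-fold lower number from compound 1 to compound 3 (0.00 log units; that floor lies within the scatter) sits at the floor and within the scatter, since (the limit of > 10000 nM in this assay, at which 2 of the 3 values shown sit). The change now in question is isopropyl in place of methyl on an aromatic carbon, which gives compound 4 `CCCCC(Sc1ccc(OCCCOc2cccc(C(C)C)c2)cc1)C(=O)O`. Going by the values given here, no measured step involves an isopropyl, and the single step from compound 1 is flat. Compound 4 is therefore expected to stay weak, with an estimated 10000 nM, between 3000 nM and 30000 nM. That expectation amounts to a step of a number no higher from compound 1 to compound 4 (the limit leaves the size open), and the result may again be only a limit.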

Compound 4, half-maximal inhibitory concentration: 6000 nM
Beside the measured number, compound 4's estimate is 1.7-fold (0.22 log units) above it; the measured number falls inside the stated range.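

In this assay, isopropyl in place of methyl gives an at least 1.6-fold lower number from compound 1 to compound 4 (0.22 log units; that floor lies within the scatter), so the bulkier carbon group yields a real number, but not a gain that can be told from the scatter. Isopropyl and trifluoromethyl cannot be separated at this position, with a 1.6-fold lower number from compound 3 to compound 4 (0.21 log units; within the scatter). The true size of the change from methyl cannot be read, because compound 1 sits at a limit of the assay: the limit of > 10000 nM in this assay, at which 2 of the 4 values shown sit.

Going by these compounds, it remains open whether any group here can shift the number beyond the scatter. An amine or a longer carbon chain at this position might answer that.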